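This account rests on a few compounds, and the source may have more. Where it says the series, first, only, none or still open, it means among the compounds named here.

Compound 1 `CC(=O)c1nnn(-c2nc(Cl)nc(Cl)n2)c1NCc1ccc(F)cc1`: 0.34 mg/kg
Compound 2 `CC(=O)c1nnn(-c2nc(Cl)nc(Cl)n2)c1NCc1ccc(Cl)cc1`: 0.39 mg/kg
Compound 3 `CC(=O)c1nnn(-c2nc(Cl)nc(Cl)n2)c1NCc1ccc(C(F)(F)F)cc1`: not yet measured

In a functional assay on the whole organism with Mus musculus as the target (a higher number here means that more compound is needed for the effect, a lower number that less compound is needed), compound 2 gives 0.39 mg/kg, and compound 1 gives 0.34 mg/kg. These two values lie within the scatter of each other, so neither compound can be separated from the other on these numbers.

Compound 3 keeps the shared core of compound 2 and carries trifluoromethyl in place of chloro on an aromatic carbon. For the measured compounds named here, only one measured step bears on this change. Chloro in place of fluoro on an aromatic carbon gave a 1.1-fold higher number from compound 1 to compound 2 (0.06 log units; within the scatter). That step was small, but it involved neither the same entering group nor a group of the same size. Going by the values given here, no compound with trifluoromethyl has been measured, so the evidence for this step is thin and gives no firm direction. On this basis, no change beyond the scatter is expected in this assay, although the uncertainty is wider than for a repeat measurement. The estimated step is a 1.1-fold higher number from compound 2 to compound 3 (0.03 log units; within the scatter). For compound 3 the expected value is 0.42 mg/kg, with an estimated range from 0.17 mg/kg to 1 mg/kg.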

Compound 3, dose for half-maximal effect: 0.21 mg/kg
For compound 3 the middle estimate is 2.0-fold (0.30 log units) above the measured one; measured number inside the range.
By their numbers in this assay, from the lowest: compounds 3, 1 and 2 (each within the scatter of the next).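

In this assay, the aromatic carbon para to a large group carries trifluoromethyl, with four heavy atoms entering where chloro had one, and the result is a 1.9-fold lower number from compound 2 to compound 3 (0.27 log units; within the scatter). Set against the fluoro compound, the same group gives a 1.6-fold lower number from compound 1 to compound 3 (0.21 log units; within the scatter), so fluoro, chloro and trifluoromethyl cannot be separated at this place on these numbers, and the extra heavy atoms bring no change that stands clear of the scatter. The earlier pair had covered only an exchange of one single halogen atom for another, whereas this result extends that reading to a group of several atoms, though nothing available explains why the numbers stay so close.

From the compounds shown here alone, all three compounds carry a halogen or a fluorine-bearing group at this place, so it remains open whether an amine, a carboxylic acid or a longer chain there would leave the number in this assay equally undisturbed. The rest of the shared core is identical throughout, and so the compounds shown say nothing about how the carbonyl or the two chloro groups contribute.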